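Smaller Alkyl Group, Same Gastric Assay

The source may hold more compounds than are shown below. What is called first, only, known or untested is meant among the compounds shown, and "the series" means these compounds.

Measured so far:
compound 1, `CC(C)(C)/N=C(\S)NCCCCn1nc(-c2ccccc2)ccc1=O`: > 100 mg/kg
compound 2, `C/N=C(/NC#N)NCCCCn1nc(Nc2ccccc2)ccc1=O`: > 100 mg/kg

In a functional assay on the whole organism (stomach) with Rattus norvegicus as the target (a higher number here means that more compound is needed for the effect, a lower number that less compound is needed), compound 1 reaches only a limit of the method, > 100 mg/kg, not a number. Compound 2 likewise stops at a limit, > 100 mg/kg. So far (the limit of > 100 mg/kg in this assay, at which 2 of the 2 values shown sit). Compound 3, `C/N=C(\S)NCCCCn1nc(-c2ccccc2)ccc1=O`, differs from compound 1 by methyl in place of tert-butyl on a double-bonded nitrogen. Going by the values given here, no step between two measured compounds is known here, so the size of this change cannot be read from the data. Compound 3 is expected to remain near the limit, making the expected step of a number no higher from compound 1 to compound 3 (the limit leaves the size open) small. The estimate for compound 3 is 100 mg/kg, ranging from 30 mg/kg to 300 mg/kg.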

Compound 3, dose for half-maximal effect: 28.9 mg/kg
For compound 3 the middle estimate is 3.5-fold (0.54 log units) above the measured one; measured number below the stated range.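

Methyl in place of tert-butyl on a double-bonded nitrogen gives an at least 3.4-fold lower number from compound 1 to compound 3 (0.53 log units; beyond the scatter), so in this assay this position does respond to the alkyl group it carries. Going by these compounds alone, compound 3 is the only compound here that gives a real number rather than a limit: the limit of > 100 mg/kg in this assay, at which 2 of the 3 values shown sit. From the compounds shown here alone, compound 1 gives only a limit, > 100 mg/kg, so the full size of the step stays unknown.

Going by these compounds, whether an ethyl or isopropyl group on this nitrogen would give a number closer to compound 3 or to compound 1 stays open. So does whether a plain hydrogen there would lower the number further.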